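Ethyl to hydrogen on the chain, carried across two cores

The source may report more compounds than this note shows. Statements on the series, on what has been measured and on what is new or still open speak of the compounds shown alone.

Compound 1 `CCCCCCCCCCn1cc(Cn2c(CC)nc3nc(C(F)(F)F)ccc3c2=O)nn1` and compound 2 `CCCCCCCCn1cc(Cn2c(CC)nc3nc(C(F)(F)F)ccc3c2=O)nn1` share one core; compound 3 `CCCCCCCCCCn1cc(COc2nc(-c3ccccc3)nc3nc(C(F)(F)F)ccc23)nn1` and compound 4 `CCCCCCCCn1cc(COc2nc(-c3ccccc3)nc3nc(C(F)(F)F)ccc23)nn1` share another. The difference between the two cores is not broken down here. In a functional assay on HeLa cells (Homo sapiens) for antiproliferative activity, read by sulforhodamine B assay, with a stated time of 48 h (on this read-out higher numbers stand for weaker inhibition of growth and lower numbers for stronger inhibition of growth), compound 1 gives 810 nM, and compound 2 gives 1270 nM. The change between them, (hydrogen in place of ethyl on a saturated chain carbon, eight bonds along the chain from an aromatic nitrogen), made a step of a 1.6-fold higher number from compound 1 to compound 2 (0.20 log units; within the scatter). In this assay compound 3 gives 1040 nM; its number lies within the scatter of both compound 1 and compound 2, so no order among the three can be drawn from these values. Compound 4 has not been measured. Among the measured compounds shown here, the change leading to it, (hydrogen in place of ethyl on a saturated chain carbon, eight bonds along the chain from an aromatic nitrogen), is the same change as the one from compound 1 to compound 2, at the same place word for word. For the measured compounds named here, with only that one earlier step to rest on, the expectation for compound 4 in this assay is a step of a 1.5-fold higher number from compound 3 to compound 4 (0.19 log units; within the scatter), on the grounds that the same change gave a 1.6-fold higher number from compound 1 to compound 2 (0.20 log units; within the scatter) on the first core. Whether the second core carries this change in the same way cannot be checked from the compounds here, and the range is set wide for that reason. Compound 4 is therefore estimated at 1600 nM in this assay, with a plausible span from 800 nM to 3500 nM.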

Compound 4, concentration for 50% growth inhibition: 950 nM
Compound 4: middle estimate off by 1.7-fold (0.23 log units), on the high side; measured number inside the range.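

In this assay, ethyl to hydrogen on a saturated chain carbon, eight bonds along the chain from an aromatic nitrogen, gives on the second core a 1.1-fold lower number from compound 3 to compound 4 (0.04 log units; within the scatter). Set beside the earlier step on the first core, the result shows no readable difference between the two cores for this change: the same change on two cores in this assay, a 1.6-fold higher number (0.20 log units; within the scatter) from compound 1 to compound 2 and a 1.1-fold lower number (0.04 log units; within the scatter) from compound 3 to compound 4, 1.7-fold (0.23 log units) apart, within the scatter of two such steps. This supports only a limited statement: within this pair of pairs, the change can be carried from one core to the other without a gap that stands out from the scatter, but neither step stands out from the scatter either, so the data show neither a real effect of the change on one core nor that the two cores respond to it alike.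

Still open, on these data alone, is whether a longer chain than that of compound 1, or a chain ending in an amine or a carboxylic acid, would give a step beyond the scatter on either core. Also open is what each part of the difference between the two cores contributes on its own, as no pair shown isolates any one of those parts.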